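A few compounds are considered here, and "the series" means these few. Any claim that something is new, unique, unknown or untested is made for them only; others in the source may bear on it.

Compound 1 `COC(=O)c1cc(-c2cnc(C(=O)CCc3ccc(-c4ccccc4)cc3)o2)ccn1` gives 1.5 nM in an assay for inhibition of Fatty-acid amide hydrolase 1 (Rattus norvegicus) (a lower number here means a stronger inhibitor, a higher number a weaker inhibitor), the lowest number among the three measured compounds; compound 3 stands nearest to it and compound 2 furthest. Compound 3 `COC(=O)c1ccc(-c2cnc(C(=O)CCc3ccc(COc4ccccc4)cc3)o2)nc1` gives 3.5 nM in this assay, while compound 2 `O=C(CCc1ccc(COc2ccccc2)cc1)c1ncc(-c2cccc(-c3nnn[nH]3)n2)o1` gives 21 nM. Among the measured compounds shown here, the one step between neighbours in the set, a 6.0-fold lower number from compound 2 to compound 3 (0.78 log units; beyond the scatter), shows that exchanging one six-membered aromatic group for another on the aromatic carbon of the shared core moves the number modestly.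

Compound 4 `CSc1cnc(C(=O)CCc2ccc(-c3ccccc3)cc2)o1` differs from compound 1 by methylsulfanyl in place of 2-(methoxycarbonyl)pyridin-4-yl on an aromatic carbon, at the aromatic carbon of the five-membered ring next to the ring oxygen, two ring bonds from the ring nitrogen. For the measured compounds named here, no measured step removes the whole six-membered ring from this position; the only step at this place, from compound 2 to compound 3, keeps a ring there and is modest in size. With a far larger group leaving than the one that enters, a clear rise in the number is expected, larger than the measured step. The expected step is a 20-fold higher number from compound 1 to compound 4 (1.30 log units; beyond the scatter) in this assay. Compound 4 is thus estimated at 30 nM, within 5 nM to 300 nM.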

Compound 4, inhibition constant: 3 nM
Compound 4: the middle estimate sits 10-fold (1.00 log units) above what was measured; measured number below the stated range.
By their numbers in this assay, from the lowest: compounds 1, 4 and 3 (each within the scatter of the next, the first and the last beyond it); then compound 2.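

At the aromatic carbon next to the ring oxygen, a 2.0-fold higher number from compound 1 to compound 4 (0.30 log units; within the scatter) in this assay, so replacing the whole 2-(methoxycarbonyl)pyridin-4-yl group with methylsulfanyl gives no step beyond the scatter. The earlier step at this place kept a six-membered aromatic ring in both compounds; this pair shows that, on the core of compound 1, such a ring is not needed for a number within the scatter of that of compound 1. No available evidence accounts for this outcome.

Still open, on these data alone, is whether the sulfur of methylsulfanyl matters, which a methoxy or ethyl group on this aromatic carbon would test. Also open, as far as these compounds go, is how far this holds for other groups at the same carbon, such as an amine or a carboxylic acid.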